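This account rests on a few compounds, and the source may have more. Where it says the series, first, only, none or still open, it means among the compounds named here.

Within the data shown here, in a functional assay on COLO 205 cells (Homo sapiens) for inhibition, read by sulforhodamine B assay, with a stated time of 48 h, tested at 50 uM (on this read-out higher numbers stand for more inhibition of growth at the one concentration tested and lower numbers for less inhibition of growth), two compounds built on the shared core have numbers so far. Among the measured compounds shown here, compound 1 `COc1cc(/C=C/C(=O)/C=C/c2cccs2)ccc1OCc1cn(CCOc2cc(=O)oc3ccccc23)nn1` gives 66% and compound 2 `COc1ccccc1/C=C/C(=O)/C=C/c1ccc(OCc2cn(CCOc3cc(=O)oc4ccccc34)nn2)c(OC)c1` gives 67%, so compound 2 stands level with the only other measured compound. Compound 3 `COc1ccc(/C=C/C(=O)/C=C/c2ccc(OCc3cn(CCOc4cc(=O)oc5ccccc45)nn3)c(OC)c2)cc1` has not been measured. It keeps everything in compound 2 except for one group: 4-methoxyphenyl in place of 2-methoxyphenyl on a double-bonded chain carbon bound to a double-bonded chain carbon, (4-methoxyphenyl in place of 2-methoxyphenyl on a double-bonded chain carbon bound to a double-bonded chain carbon). For the measured compounds named here, only one measured step bears on this place, the exchange of thiophen-2-yl for 2-methoxyphenyl, which gave a number 1 percentage points higher from compound 1 to compound 2 (within the scatter). Going by the values given here, on that single step, no change beyond the scatter is expected in this assay, though no measured step tests the 4-methoxyphenyl group itself. The expected step is a number 1 percentage points lower from compound 2 to compound 3 (within the scatter). Compound 3 is estimated at 66%, with an expected range from 54% to 77%.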

Compound 3, percent growth inhibition at one concentration: 68%
The estimate for compound 3 lay 2 percentage points below the measured number; the range from low to high includes it.
By their numbers in this assay, from the lowest: compounds 1, 2 and 3 (each within the scatter of the next).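

In this assay, among these compounds, 4-methoxyphenyl in place of 2-methoxyphenyl on a double-bonded chain carbon bound to a double-bonded chain carbon gives a number 1 percentage points higher from compound 2 to compound 3 (within the scatter), so for the first time the same methoxy-bearing phenyl group is tested in two forms at this place, and the two forms cannot be told apart. Against thiophen-2-yl, the 4-methoxyphenyl group gives a number 2 percentage points higher from compound 1 to compound 3 (within the scatter), which means that all three groups at this place fall within the scatter of one another. No measurement available here offers an explanation for this flat result.

From the compounds shown here alone, it remains open whether a phenyl group carrying an amine or a carboxylic acid at this place would move the number beyond the scatter. The single tested concentration also leaves any difference in potency among these three compounds unresolved.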